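The compounds below may be only part of what the source reports. "The series", "measured", "known", "first", "only" and "open" are said of these compounds alone.

Compound 1 `O=C(Nc1ccc(Cl)cc1F)C(=O)N1CCC(c2ccnc3ccc(F)cc23)CC1` is the weaker of the two measured compounds by the numbers, although its nearest neighbour sits within the scatter. Going by the values given here, in an assay on HEK cells for inhibition of Tryptophan 2,3-dioxygenase (Homo sapiens) (on this read-out lower numbers stand for stronger inhibition and higher numbers for weaker inhibition), compound 1 gives 6700 nM, while compound 2 `O=C(Nc1ccc(C(F)F)cc1)C(=O)N1CCC(c2ccnc3ccc(F)cc23)CC1` gives 5800 nM; the single measured step, a 1.2-fold lower number from compound 1 to compound 2 (0.06 log units; within the scatter), also changes the group on the amide-type nitrogen and so bears on the present case. Compound 3 `O=C(Nc1ccc(Cl)cn1)C(=O)N1CCC(c2ccnc3ccc(F)cc23)CC1` carries 5-chloropyridin-2-yl in place of 4-chloro-2-fluorophenyl on an amide-type nitrogen. Because a 1.2-fold lower number from compound 1 to compound 2 (0.06 log units; within the scatter) stayed within the scatter, compound 3 is expected to show no step beyond it, a 1.1-fold lower number from compound 1 to compound 3 (0.05 log units; within the scatter). Compound 3 is therefore estimated at 6000 nM, within 2500 nM to 15000 nM.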

Compound 3, half-maximal inhibitory concentration: 5900 nM
Estimate against measurement, compound 3: 1.0-fold (0.01 log units) above; the measured number falls inside the stated range.
By their numbers in this assay, from the lowest: compounds 2, 3 and 1 (each within the scatter of the next).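

In this assay, a ring with a hetero atom in place of the carbon-only ring on the amide-type nitrogen gives a 1.1-fold lower number from compound 1 to compound 3 (0.06 log units; within the scatter) and so stays within the scatter. The comparison with the difluoromethyl compound gives a 1.0-fold higher number from compound 2 to compound 3 (0.01 log units; within the scatter) and also stays within it. This position has thus taken a 5-chloropyridin-2-yl group, which brings a hydrogen-bond acceptor, with no step beyond the scatter, and nothing given here bears on why these numbers lie so close. Still open, as far as these compounds go, is whether a non-aromatic group on this nitrogen, such as a cyclohexyl ring, an amine or a carboxylic acid, would move the number beyond the scatter.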